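Swapping a hydroxyethyl for a nitrile on the phenyl

The source may report more compounds than this note shows. Statements on the series, on what has been measured and on what is new or still open speak of the compounds shown alone.

Compound 1 `CC(Sc1nc2c(cnn2C)c(=O)n1-c1ccc(CCO)cc1)c1ccccc1` is tested in an assay on isolated protein for inhibition of retinal dehydrogenase 2 (Homo sapiens) (on this read-out lower numbers stand for stronger inhibition and higher numbers for weaker inhibition), where compound 1 gives 216 nM. Among the three measured compounds this is the highest number. Compound 2 `CC(Sc1nc2c(cnn2C)c(=O)n1-c1ccccc1)c1cccc(F)c1` gives 110 nM in this assay, and this gap to compound 1 lies within the scatter of repeated measurements, so the two cannot be ranked against each other. Compound 3 `CC(Sc1nc2nn(C3COC3)cc2c(=O)n1-c1ccccc1)c1ccccn1` gives 21 nM in this assay, a number that sits clearly lower than that of compound 1 and beyond the scatter. Both compound 2 and compound 3 differ from compound 1 in more than one place, so their numbers only show how wide the series spreads.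

Compound 4 `CC(Sc1nc2c(cnn2C)c(=O)n1-c1ccc(C#N)cc1)c1ccccc1` has not yet been measured. It differs from compound 1 in one place: cyano in place of 2-hydroxyethyl on an aromatic carbon. For the measured compounds named here, no measured pair shares this change, so nothing in the data says how large a step to expect or in which direction. With that in mind, the expected step from compound 1 to compound 4 is small, estimated as a 1.4-fold lower number from compound 1 to compound 4 (0.16 log units; within the scatter), which may well fall within the scatter. For compound 4 the estimate in this assay is 150 nM, with a range from 50 nM to 450 nM.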

Compound 4, half-maximal inhibitory concentration: 3100 nM
The estimate for compound 4 lay 21-fold (1.32 log units) below the measured number; the measured number lies above the stated range.
By their numbers in this assay, from the lowest: compound 3; then compounds 2 and 1 (each within the scatter of the next); then compound 4.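

In this assay, replacing the 2-hydroxyethyl with cyano gives a large change: a 14-fold higher number from compound 1 to compound 4 (1.16 log units; beyond the scatter). For the compounds shown here, this is the first step that isolates a single place, and it shows that the group on this aromatic carbon, para to a large group, can move the number well beyond the scatter, which the earlier comparisons with several differences could not show. Nothing at hand explains the size or direction of this step.

The change removes a hydrogen-bond donor, shortens the substituent and brings in a triple bond all at once, so the compounds shown cannot tell which of these differences matters, or whether compound 1 gains from its 2-hydroxyethyl or compound 4 loses from its cyano. A plain hydrogen, an ethyl or a 2-methoxyethyl at the same place on the core of compound 1 would help separate these possibilities, with the hydrogen showing how each of the two groups compares with having no group there at all.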